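From Free Acid to an Alkyl Ester: an Expected Gain

The compounds below may be only part of what the source reports. "The series", "measured", "known", "first", "only" and "open" are said of these compounds alone.

Compound 1 `CC(C)c1cccc(C(C)C)c1NC(=O)CC(=O)Oc1c(C(C)C)cccc1C(C)C` and compound 2 `CC(C)c1cccc(C(C)C)c1NC(=O)CC(=O)O` have both been tested. In an assay on microsomes from intestine for inhibition of acyl-CoA:cholesterol acyltransferase (Oryctolagus cuniculus) (a lower number here means a stronger inhibitor, a higher number a weaker inhibitor), compound 1 gives 42 nM. Compound 2 reaches only a limit of this assay, > 5000 nM; its place among the numbers shown is the limit of > 5000 nM in this assay, at which 1 of the 2 values shown sits, not a measured value. Compound 3 `CCCCCC(C)OC(=O)CC(=O)Nc1c(C(C)C)cccc1C(C)C` is not yet measured and carries 1-methylhexyl in place of hydrogen on an oxygen next to a carbonyl group. Within the data shown here, no step between measured compounds is known here, so any size is an expectation. In this assay the step of an at least 25-fold lower number from compound 2 to compound 3 (1.39 log units; beyond the scatter) is expected, toward stronger inhibition. Compound 3 is therefore estimated at 200 nM, within 30 nM to 1500 nM.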

Compound 3, half-maximal inhibitory concentration: 27 nM
Estimate against measurement, compound 3: 7.4-fold (0.87 log units) above; measured number outside the range, below it.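

In this assay, 1-methylhexyl on this oxygen brings an at least 180-fold lower number from compound 2 to compound 3 (2.26 log units; beyond the scatter), so an open chain with no ring is enough for a large gain over the free acid. The value of compound 2, > 5000 nM, is a limit and not a number, so that step is only a minimum: the limit of > 5000 nM in this assay, at which 1 of the 3 values shown sits. Compound 3 gives 27 nM and compound 1 gives 42 nM, two values within the usual scatter of each other, although only compound 1 carries a ring in this place.

On these data alone, whether a shorter chain such as ethyl or a longer chain would serve as well remains open. So does whether the methyl branch matters, which unbranched heptyl would test.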